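A few compounds are considered here, and "the series" means these few. Any claim that something is new, unique, unknown or untested is made for them only; others in the source may bear on it.

In a functional assay on the whole organism (artery, strain albino) with Rattus norvegicus as the target, with a stated time of 360 min, at a dose of 10 mg/kg by the oral route (on this read-out lower numbers stand for less inhibition and higher numbers for more inhibition at the one dose given (going by the name of the read-out)), compound 1 `CC1=C(C(=O)Nc2ccc([N+](=O)[O-])cc2)C(c2ccc(Br)cc2)N=C(SCc2ccc(F)cc2)N1` gives 38.7%, and compound 2 `CC1=C(C(=O)Nc2ccc([N+](=O)[O-])cc2)C(c2cccc([N+](=O)[O-])c2)N=C(SCc2ccc(Cl)cc2)N1` gives 33%. Compound 2 thus lies within the usual scatter of compound 1, so the two numbers cannot be told apart on this read-out. Compound 3 `CC1=C(C(=O)Nc2ccc([N+](=O)[O-])cc2)C(c2cccc([N+](=O)[O-])c2)N=C(SCc2ccc(F)cc2)N1` differs from compound 2 by fluoro in place of chloro on an aromatic carbon. Among the measured compounds shown here, no measured pair here isolates this exchange, so the step from it is expected to stay within the scatter, with no clear direction. Compound 3 is therefore estimated to give 35% in this assay, in the range 22% to 48%, which would mean an expected step of a number 2 percentage points higher from compound 2 to compound 3 (within the scatter).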

Compound 3, a percentage reported as inhibition, in the whole organism at one dose (the size of the read-out at that dose, not a potency): 36.1%
Beside the measured number, compound 3's estimate is 1.1 percentage points below it; low and high end bracket the measured number.
By their numbers in this assay, from the lowest: compounds 2, 3 and 1 (each within the scatter of the next).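

In this assay, fluoro in place of chloro on the aromatic carbon of the benzyl group gives a number 3.1 percentage points higher from compound 2 to compound 3 (within the scatter), so this halogen exchange produces no readable difference. 3-Nitrophenyl in place of 4-bromophenyl on the saturated ring carbon gives a number 2.6 percentage points lower from compound 1 to compound 3 (within the scatter), which likewise cannot be told apart. Nothing available accounts for either result. As far as these compounds go, whether an amine or a carboxylic acid on this aromatic carbon would move the number beyond the scatter stays open. So does the outcome of a longer chain in place of the benzyl group.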